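Phenylsulfonyl for (tert-butyl)carbonyl: an Expected Toxicity Outcome

The compounds below may be only part of what the source reports. "The series", "measured", "known", "first", "only" and "open" are said of these compounds alone.

Compound 1 `O=C(Nc1ncc(Cc2ccc(F)cc2)s1)c1ccc(Cl)cc1Cl`: > 50000 nM
Compound 2 `CC(C)(C)C(=O)Nc1ncc(C(Oc2ccc3cc(Br)ccc3c2)c2ccc(Cl)cc2)s1`: "not toxic" (no number reported)

Both measured compounds were tested in an ADME assay on HepG2 2.2.15 cells (Homo sapiens) for cytotoxicity; on this read-out higher numbers stand for lower toxicity in this test and lower numbers for higher toxicity in this test. Compound 1 reaches only a limit of the assay there, > 50000 nM, and not a number. Compound 2 was recorded in this assay as "not toxic" (no number reported), with no figure attached, so where it stands can be said only this far: one of the two values shown sits at the limit of > 50000 nM in this assay, at which 1 of the 2 values shown sits, and the other is a word without a number. Going by the values given here, no step between measured compounds is available; compound 1 and compound 2 differ in more than one place.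

Compound 3 `O=S(=O)(Nc1ncc(C(Oc2ccc3cc(Br)ccc3c2)c2ccc(Cl)cc2)s1)c1ccccc1` is the next compound, still unmeasured in this assay. It differs from compound 2 in one place: phenylsulfonyl in place of (tert-butyl)carbonyl on a nitrogen on an aromatic ring. With neither measured compound showing toxicity in this assay, the step from compound 2 to compound 3 is expected to bring no change beyond the scatter of the test, and most probably ends again at a limit. The half-maximal cytotoxic concentration of compound 3 in this assay is expected near 50000 nM, within 20000 nM to 100000 nM.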

Compound 3, half-maximal cytotoxic concentration: > 50000 nM
Compound 3: a limit, no number; the forecaster's own chance of this, stated with the estimate: 70%; the middle value lies on the limit itself.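

Going by these compounds alone, no step from compound 2 to compound 3 can be read in this assay, as compound 2 carries a word and no number. Compound 3 gives > 50000 nM, which is a limit of the assay and not a number. The compounds shown leave open where each half-maximal cytotoxic concentration lies, and whether phenylsulfonyl in place of (tert-butyl)carbonyl changes it at all.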